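The source may report more compounds than this note shows. Statements on the series, on what has been measured and on what is new or still open speak of the compounds shown alone.

Measured so far:
Compound 1, `Nc1nc([SeH])nc2ncccc12`: 61500 nM
Compound 2, `CCCCC[Se]c1nc(N)c2cccnc2n1`: 42800 nM
Compound 3, `Nc1nc([SeH])nc2ccccc12`: 52400 nM

All three values come from a functional assay on CCRF-CEM cells (Homo sapiens) for cytotoxicity, read by MTT assay, with a stated time of 72 h; on this read-out higher numbers stand for weaker inhibition of growth and lower numbers for stronger inhibition of growth. Compound 1 and compound 3 share the same arrangement of a selenium bearing a hydrogen and an amino group, but sit on different cores; the difference between the two cores is not broken down here. Their values lie within the usual scatter of each other, so nothing can be said about an order between them.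

Compound 2 is made from compound 1 by one change, (pentyl in place of hydrogen on a selenium). This gave a 1.4-fold lower number from compound 1 to compound 2 (0.16 log units; within the scatter), a step too small to count as real.

Compound 4, `CCCCC[Se]c1nc(N)c2ccccc2n1`, stands to compound 3 exactly as compound 2 stands to compound 1: the change is pentyl in place of hydrogen on a selenium, the same change, at the same kind of place. For the measured compounds named here, the expected step in this assay rests on the single earlier example: since a 1.4-fold lower number from compound 1 to compound 2 (0.16 log units; within the scatter) was within the scatter, the expected step is a 1.4-fold lower number from compound 3 to compound 4 (0.14 log units; within the scatter). Compound 4 is therefore estimated to give 38000 nM, with a range from 18000 nM to 80000 nM, and this estimate awaits the measurement.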

Compound 4, concentration for total growth inhibition: 68000 nM
Beside the measured number, compound 4's estimate is 1.8-fold (0.25 log units) below it; the measured number falls inside the stated range.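

In this assay, putting pentyl in place of hydrogen on a selenium gives a 1.3-fold higher number from compound 3 to compound 4 (0.11 log units; within the scatter). Set beside the same change on the other core, the two steps cannot be told apart: the same change on two cores in this assay, a 1.4-fold lower number (0.16 log units; within the scatter) from compound 1 to compound 2 and a 1.3-fold higher number (0.11 log units; within the scatter) from compound 3 to compound 4, 1.9-fold (0.27 log units) apart, within the scatter of two such steps. This shows that, on both of these cores, the change leaves the number within the usual scatter of repeated measurements, so neither core gives any sign that pentyl on the selenium alters growth inhibition in these cells; it does not show that the change has no effect at all, since an effect smaller than the scatter would go unseen, and two pairs of compounds cannot establish a rule for the whole series.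

The compounds shown leave open whether a different group on the selenium, such as methyl, a longer chain than pentyl, or a chain carrying an amine or a carboxylic acid, would move the number beyond the scatter. They also leave open whether such a group would act alike on both cores.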